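Removing a Chlorine from an Inactive Anticonvulsant Candidate

A few compounds are considered here, and "the series" means these few. Any claim that something is new, unique, unknown or untested is made for them only; others in the source may bear on it.

Two compounds share a core in which a succinimide ring is joined through a short carbon chain to an amide carbonyl that carries a phenylpiperazine. Compound 1 `CC(C(=O)N1CCN(c2ccccc2)CC1)N1C(=O)CCC1=O` and compound 2 `CCC(C(=O)N1CCN(c2cccc(Cl)c2)CC1)N1C(=O)CCC1=O` were tested in a functional assay on the whole organism (strain Swiss) with Mus musculus as the target, in the maximal electroshock model, with a stated time of 1 h, at a dose of 100 mg/kg by the intraperitoneal route; on this read-out lower numbers stand for a weaker effect and higher numbers for a stronger effect at the one dose given. Compound 1 gives 0% in this assay. Compound 2 gives 0% in this assay, so compound 2 stands level with compound 1 within the scatter; neither shows any protection at the dose used.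

Compound 3 `CCC(C(=O)N1CCN(c2ccccc2)CC1)N1C(=O)CCC1=O` has not yet been measured. Compound 3 differs from compound 2 in one place: hydrogen in place of chloro on an aromatic carbon. Because compound 2 gives 0% and compound 1 gives 0%, with no step beyond the scatter between them, no step beyond the scatter is expected for this change either. Compound 3 is expected to give 0% in this assay, with an expected range of 0% to 20%, a step of no change at the digits printed from compound 2 to compound 3 (within the scatter) that is estimated to lie within the scatter.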

Compound 3, a percentage reported as activity, at one dose (the size of the read-out at that dose, not a potency): 0%
For compound 3 middle estimate and measured number coincide at the digits printed, and the stated range covers the measured number.
By their numbers in this assay, from the lowest: compounds 1, 2 and 3 (each within the scatter of the next).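

Compounds 1 and 2 differ in more than one place, and compound 3 now links them through two single changes. In this assay, the 3-chlorophenyl to phenyl change gives no change at the digits printed from compound 2 to compound 3 (within the scatter), while methyl in place of hydrogen on the saturated chain carbon gives no change at the digits printed from compound 1 to compound 3 (within the scatter). With no protection seen at either end of these steps, neither change switches on any activity at this dose, and nothing available accounts for this flat result.

What the compounds shown leave open is whether either position matters at all in a compound that does protect. A trifluoromethyl group on the aromatic ring or a longer chain in place of the methyl might still give a response in this assay.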